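Swapping Fluoro for Ethynyl on a Shared Core

The compounds below may be only part of what the source reports. "The series", "measured", "known", "first", "only" and "open" are said of these compounds alone.

Two measured compounds share one core and differ only in the fused ring system at its end. Compound 1 `CC(C)(C)c1cc(NC(=O)Nc2ccc(-c3cc4ccccc4s3)cc2)no1` gives in a functional assay on MV4-11 cells (Homo sapiens) for cytotoxicity, read by MTT assay, with a stated time of 72 h (a lower number here means a stronger inhibitor, a higher number a weaker inhibitor), only a limit, > 900 nM, which is a boundary of the assay rather than a number, as the limit of > 900 nM in this assay, at which 1 of the 2 values shown sits, records. Among the measured compounds shown here, compound 2 `CC(C)(C)c1cc(NC(=O)Nc2ccc(-c3cn4cc(F)ccc4n3)cc2)no1` gives in this assay 20.9 nM, the only true number among the two results, so it stands as the sole reference point. Compound 3 `C#Cc1ccc2nc(-c3ccc(NC(=O)Nc4cc(C(C)(C)C)on4)cc3)cn2c1` is not yet measured; it differs from compound 2 by ethynyl in place of fluoro on an aromatic carbon. For the measured compounds named here, no measured pair shows what such a swap does here, so the step from compound 2 to compound 3 in this assay is expected to be small, within the scatter or slightly weaker: a 1.4-fold higher number from compound 2 to compound 3 (0.16 log units; within the scatter). Compound 3 is therefore estimated at 30 nM, with a range from 8 nM to 120 nM.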

Compound 3, half-maximal inhibitory concentration: 8.62 nM
For compound 3 the middle estimate is 3.5-fold (0.54 log units) above the measured one; the range from low to high includes it.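

Placing ethynyl in place of fluoro on this aromatic carbon gives a 2.4-fold lower number from compound 2 to compound 3 (0.38 log units; beyond the scatter) in this assay, the first step here that compares two real numbers. The position, para to a fused ring, therefore takes two carbons in place of one fluorine, and the number falls rather than rises, so compound 3 is the stronger inhibitor of this pair. Nothing measured here explains why the swap helps.

On these data alone, a single swap at a single position gives no trend, so it stays open whether the gain is specific to ethynyl or would also appear with an amine, a nitrile or a longer alkyne chain at the same carbon. As far as these compounds go, it is also open whether the gain would hold in any other assay.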